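The source may hold more compounds than are shown below. What is called first, only, known or untested is meant among the compounds shown, and "the series" means these compounds.

Compound 1 `CC(=O)N[C@@H]1CCC[C@H](C(=O)Nc2cc(-c3cnn(C)c3C)c(Cl)cn2)C1` has the lowest of the two numbers in an ADME assay on microsomes from liver (Homo sapiens) for metabolic stability (on this read-out higher numbers stand for fast clearance and lower numbers for slow clearance), giving 3.3 mL.min-1.g-1, while compound 2 `CC(=O)N[C@@H]1CCC[C@H](C(=O)Nc2cc(-c3cnn4c3CC(C)(C)CC4)c(F)cn2)C1` gives 178 mL.min-1.g-1, a gap that lies beyond the scatter. Compound 3 `CC(=O)N[C@@H]1CCC[C@H](C(=O)Nc2cc(-c3cnc4n3CC(C)(C)C4)c(Cl)cn2)C1` differs from compound 1 in one place: a group of 10 heavy atoms (8 carbon, 2 nitrogen; one five-membered non-aromatic ring with 1 hetero atom, one five-membered aromatic ring with 2 hetero atoms) in place of a group of 7 heavy atoms (5 carbon, 2 nitrogen; one five-membered aromatic ring with 2 hetero atoms), on an aromatic carbon. Among the measured compounds shown here, no measured pair shows this exact step, so its size rests only on the two values known. Because compound 2 gives 178 mL.min-1.g-1, compound 3 is expected to shift toward faster clearance by a 12-fold higher number from compound 1 to compound 3 (1.08 log units; beyond the scatter). The estimated result of compound 3 in this assay is 40 mL.min-1.g-1, within a range from 10 mL.min-1.g-1 to 150 mL.min-1.g-1.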

Compound 3, intrinsic clearance in microsomes: 63 mL.min-1.g-1
Compound 3: middle estimate off by 1.6-fold (0.20 log units), on the low side, and the stated range covers the measured number.
By their numbers in this assay, from the lowest: compound 1; then compound 3; then compound 2.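

At the aromatic carbon ortho to a chloro group, putting a group with one five-membered non-aromatic ring and one five-membered aromatic ring in place of 1,5-dimethyl-1H-pyrazol-4-yl gives a 19-fold higher number from compound 1 to compound 3 (1.28 log units; beyond the scatter) in this assay. Among the compounds shown here, this is the first change at this position that can be read on its own. The step is large, although the counts of hydrogen-bond donors and acceptors and the net charge stay the same.

From the compounds shown here alone, whether an amine or a carboxylic acid on the entering group would keep the number close to that of compound 1 remains open. No measurement shown accounts for the rise.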